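This account rests on a few compounds, and the source may have more. Where it says the series, first, only, none or still open, it means among the compounds named here.

The study concerns three compounds built on one shared core. Compound 1 `N#CC1=C(N)Oc2c(N)cc3nc4ccccc4nc3c2C12C(=O)N(Cc1cnnn1-c1cccc(C(F)(F)F)c1)c1ccccc12` carries a 3-(trifluoromethyl)phenyl group on the aromatic nitrogen of its five-membered aromatic ring with three nitrogens, and in a functional assay on MCF7 cells (Homo sapiens) for antiproliferative activity, read by MTT assay, with a stated time of 48 h (on this read-out higher numbers stand for weaker inhibition and lower numbers for stronger inhibition), compound 1 gives 31600 nM. Compound 2 `Cc1ccc(-n2nncc2CN2C(=O)C3(C(C#N)=C(N)Oc4c(N)cc5nc6ccccc6nc5c43)c3ccccc32)cc1C` carries 3,4-dimethylphenyl in that place. In this assay compound 2 reaches only a limit of the assay, > 50000 nM. The step of an at least 1.5-fold higher number from compound 1 to compound 2 (0.19 log units; that floor lies within the scatter) is thus known only as a floor, and compound 2 stands at the limit of > 50000 nM in this assay, at which 1 of the 2 values shown sits. Compound 3 `CCc1cccc(C)c1-n1nncc1CN1C(=O)C2(C(C#N)=C(N)Oc3c(N)cc4nc5ccccc5nc4c32)c2ccccc21` differs from compound 2 by 2-ethyl-6-methylphenyl in place of 3,4-dimethylphenyl on an aromatic nitrogen. Among the compounds with values here, only the step between compound 1 and compound 2 touches the same aromatic nitrogen, and it shows no change beyond the scatter, so no step beyond the scatter is expected in this assay from this exchange either. Compound 3 is therefore expected to remain at the limit, estimated at 60000 nM with a range from 25000 nM to 150000 nM, a step that the limit leaves unreadable from compound 2 to compound 3.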

Compound 3, half-maximal inhibitory concentration: > 50000 nM
Compound 3: no number, only a limit (the forecaster's own chance of this, stated with the estimate: 70%); the middle value does not contradict the limit.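

In this assay compound 3 gives > 50000 nM, which is a limit of the assay and not a number, so 2-ethyl-6-methylphenyl is a second group after 3,4-dimethylphenyl on this aromatic nitrogen to yield no readable value. Exchanging 3-(trifluoromethyl)phenyl for 2-ethyl-6-methylphenyl gives an at least 1.5-fold higher number from compound 1 to compound 3 (0.19 log units; that floor lies within the scatter), so this change, like the earlier one at the same position, is known only as a floor and shows nothing beyond the scatter. The step between 3,4-dimethylphenyl and 2-ethyl-6-methylphenyl cannot be read, and the limit now holds most of the series: the limit of > 50000 nM in this assay, at which 2 of the 3 values shown sit.

From the compounds shown here alone, it remains open how far compound 2 and compound 3 lie past their limits. Going by these compounds, it is also open whether a phenyl ring carrying an amine or a carboxylic acid on this nitrogen would give a readable value.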